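Aryl replacement on the aminopyrimidine of an indole kinase inhibitor

This account rests on a few compounds, and the source may have more. Where it says the series, first, only, none or still open, it means among the compounds named here.

Compound 1 `Cc1[nH]c2ccccc2c1-c1ccnc(NCCO)n1`: 11000 nM
Compound 2 `COCCCNc1nccc(-c2c(C)[nH]c3ccccc23)n1`: 1500 nM
Compound 3 `Cc1[nH]c2ccccc2c1-c1ccnc(Nc2ccccc2Cl)n1`: 19000 nM

In an assay on isolated protein for inhibition of interferon-induced, double-stranded RNA-activated protein kinase (Homo sapiens), read by luminescence, with a stated time of 10 min (a higher number here means a weaker inhibitor, a lower number a stronger inhibitor), compound 3 stands at the highest number of the three measured compounds. Its gap to compound 1 is within the scatter, whereas a 13-fold higher number from compound 2 to compound 3 (1.10 log units; beyond the scatter) is a large step. Compound 4 `Cc1[nH]c2ccccc2c1-c1ccnc(Nc2ccc(F)c(F)c2)n1` differs from compound 3 by 3,4-difluorophenyl in place of 2-chlorophenyl on a nitrogen on an aromatic ring. Going by the values given here, none of the measured steps exchanges one aryl group for another; the two informative steps, a 7.3-fold lower number from compound 1 to compound 2 (0.87 log units; beyond the scatter) and a 13-fold higher number from compound 2 to compound 3 (1.10 log units; beyond the scatter), concern a chain or a chain set against an aryl group, so they bear only loosely on this change. The step is therefore expected to be a 1.3-fold lower number from compound 3 to compound 4 (0.10 log units; within the scatter), a shift within or barely beyond the scatter. For compound 4 the estimate is 15000 nM, with a range from 5000 nM to 45000 nM.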

Compound 4, half-maximal inhibitory concentration: 1500 nM
For compound 4 the middle estimate is 10-fold (1.00 log units) above the measured one, outside the stated range (below it).
By their numbers in this assay, from the lowest: compounds 2 and 4 (each within the scatter of the next); then compounds 1 and 3 (each within the scatter of the next).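

In this assay, the aryl group on this nitrogen matters: 3,4-difluorophenyl in place of 2-chlorophenyl gives a large step (a 13-fold lower number from compound 3 to compound 4 (1.10 log units; beyond the scatter)). An aryl group is thus not poor here as such, since 3,4-difluorophenyl matches 3-methoxypropyl (no change at the digits printed from compound 2 to compound 4 (within the scatter)). It also improves on 2-hydroxyethyl (a 7.3-fold lower number from compound 1 to compound 4 (0.87 log units; beyond the scatter)).

Where an unsubstituted phenyl or a 4-fluorophenyl would stand remains open, so the step cannot be assigned to a single change in the halogens. Nothing measured here explains the step.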